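Replacing the cyanopyridine of compound 3 with an open chain

This account rests on a few compounds, and the source may have more. Where it says the series, first, only, none or still open, it means among the compounds named here.

Measured in a functional assay on EBC-1 cells (Homo sapiens) for antiproliferative activity, with a stated time of 72 h; a lower number here means a stronger inhibitor, a higher number a weaker inhibitor:
- compound 1 `Cn1cc(-c2cn3c(Cc4ccc5ncccc5c4)cnc3cc2C#N)cn1`: "not determined" (no result reported)
- compound 2 `Fc1cc(-c2cnn(C3CCNCC3)c2)cn2c(Cc3ccc4ncccc4c3)cnc12`: 1.46 nM
- compound 3 `N#Cc1ccc(-c2cc(F)c3ncc(Cc4ccc5ncccc5c4)n3c2)cn1`: 189 nM

Among the measured compounds shown here, compound 1 has no number, so only two values can be compared. Compound 3, at 189 nM, holds the higher of the two. Compound 2, at 1.46 nM, lies lower, and the gap between them is beyond the scatter.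

The next compound to be tested in this assay is compound 4 `CCO/N=C(\C)c1cc(F)c2ncc(Cc3ccc4ncccc4c3)n2c1`. It differs from compound 3 at a single place: a group of 6 heavy atoms (4 carbon, 1 nitrogen, 1 oxygen; no ring) in place of a group of 8 heavy atoms (6 carbon, 2 nitrogen; one six-membered aromatic ring with 1 hetero atom), on an aromatic carbon. The 6-cyanopyridin-3-yl group leaves an aromatic carbon, meta to a fluoro group, and a group with no ring takes its place.

For the measured compounds named here, no measured compound carries this entering group, and no step between measured compounds that differ in one place is available. The expectation therefore starts from compound 3 at 189 nM, with a wide margin on both sides. The gap to compound 2 at 1.46 nM shows how far the values in this small set can spread. The expected change is small and slightly downward, not beyond the scatter: a 1.6-fold lower number from compound 3 to compound 4 (0.20 log units; within the scatter). For compound 4 the estimated value is 120 nM, with an expected range of 15 nM to 800 nM.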

Compound 4, half-maximal inhibitory concentration: 1480 nM
For compound 4 the middle estimate is 12-fold (1.09 log units) below the measured one; measured number outside the range, above it.
By their numbers in this assay, from the lowest: compound 2; then compound 3; then compound 4.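

In this assay, among the compounds shown here, the open chain at this aromatic carbon, meta to a fluoro group, gives a 7.8-fold higher number from compound 3 to compound 4 (0.89 log units; beyond the scatter), the first direct reading of a single change at this position. Both the leaving and the entering group count 2 hydrogen-bond acceptors and 0 hydrogen-bond donors, so the exchange leaves those counts unchanged while the six-membered aromatic ring is lost and the heavy-atom count goes from 8 to 6, and the higher number goes with that change in this one pair only. No measurement at hand bears on why the number rises.

For the compounds shown here, the single pair cannot separate the loss of the ring from the nature of the chain, so it remains open whether a longer chain ending in an amine or a carboxylic acid would read differently at this position. As far as these compounds go, it also remains open how a saturated ring such as morpholine or piperidine, attached directly at this carbon, would compare with the 6-cyanopyridin-3-yl group of compound 3.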